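A Methyl for a Chloro on the Aryl Group

This account rests on a few compounds, and the source may have more. Where it says the series, first, only, none or still open, it means among the compounds named here.

In a functional assay on SK-MEL-2 cells (Homo sapiens) for cytotoxicity (on this read-out higher numbers stand for weaker inhibition and lower numbers for stronger inhibition), compound 1 `Cc1ccc2c(O)nc(-c3ccccc3)cc2c1` gives 1580 nM as its number, compound 2 `COc1ccc(-c2cc3cc(C)ccc3c(N3CCN(C)CC3)n2)cc1` gives 3710 nM and compound 3 `Cc1ccc2c(N3CCN(C)CC3)nc(-c3ccc(Cl)cc3)cc2c1` gives 2400 nM on the same read-out. Compound 3 lies within the scatter of both compound 1 and compound 2, so its place among these three numbers carries little weight. Compound 4 `Cc1ccc2c(N3CCN(C)CC3)nc(-c3ccccc3C)cc2c1` has not yet been measured. The change 2-methylphenyl in place of 4-chlorophenyl on an aromatic carbon puts 2-methylphenyl in place of 4-chlorophenyl on an aromatic carbon next to the ring nitrogen. For the measured compounds named here, the one measured step that bears on this is a 1.5-fold lower number from compound 2 to compound 3 (0.19 log units; within the scatter) with chloro in place of methoxy on an aromatic carbon. Going by the values given here, no measured compound carries 2-methylphenyl, so that small step is only a weak guide. In this assay a change no larger than the scatter is therefore expected, with no firm direction. The estimated step is a 1.2-fold higher number from compound 3 to compound 4 (0.07 log units; within the scatter) and nothing more is expected of it. Compound 4 is estimated at 2800 nM with a range of 1300 nM to 6000 nM on this read-out.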

Compound 4, half-maximal inhibitory concentration: 3380 nM
For compound 4 the middle estimate is 1.2-fold (0.08 log units) below the measured one; low and high end bracket the measured number.
By their numbers in this assay, from the lowest: compounds 1, 3, 4 and 2 (each within the scatter of the next, the first and the last beyond it).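

In this assay, 2-methylphenyl replacing 4-chlorophenyl gives a 1.4-fold higher number from compound 3 to compound 4 (0.15 log units; within the scatter), and 2-methylphenyl replacing 4-methoxyphenyl gives a 1.1-fold lower number from compound 2 to compound 4 (0.04 log units; within the scatter). The aromatic carbon next to the ring nitrogen has now carried three different substituted phenyl groups, and compounds 2, 3 and 4 cannot be told apart on this read-out, even though the 2-methylphenyl group differs from the other two in both its substituent and where that substituent sits. Nothing available explains these small differences.

On these data alone, whether an aryl group bearing an aminomethyl group or a carboxylic acid would move the number beyond the scatter remains open. As far as these compounds go, compounds 2, 3 and 4 all keep the 4-methylpiperazin-1-yl group, so the effect of changing that group alone also remains unknown.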